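A second 1H-benzimidazol-2-yl group for compound 2

A few compounds are considered here, and "the series" means these few. Any claim that something is new, unique, unknown or untested is made for them only; others in the source may bear on it.

Compound 1 `N#Cc1cc(-c2ccccc2)n(-c2ccncc2)c1N` gives 10700 nM
Compound 2 `Nc1c(-c2nc3ccccc3[nH]2)cc(-c2ccccc2)n1-c1ccncc1` gives 1100 nM

In a functional assay on A549 cells (Homo sapiens) for cytotoxicity, read by resazurin assay, with a stated time of 72 h (on this read-out higher numbers stand for weaker inhibition and lower numbers for stronger inhibition), compound 2 holds the lower of the two numbers at 1100 nM and is the stronger inhibitor of the pair. Going by the values given here, compound 3 `Nc1c(-c2nc3ccccc3[nH]2)cc(-c2ccccc2)n1-c1nc2ccccc2[nH]1` has 1H-benzimidazol-2-yl in place of pyridin-4-yl on an aromatic nitrogen and no measured step covers this place. The nearest guide is a 9.7-fold lower number from compound 1 to compound 2 (0.99 log units; beyond the scatter) which brought in the same group in place of cyano on an aromatic carbon, a modest change beyond the scatter. That change sat elsewhere, so in this assay only a small fall, probably within the scatter, is expected. The estimated change is a 1.4-fold lower number from compound 2 to compound 3 (0.14 log units; within the scatter) on this reasoning. Compound 3 is estimated at 800 nM (expected range 200 nM to 3500 nM).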

Compound 3, half-maximal inhibitory concentration: 7700 nM
Estimate against measurement, compound 3: 9.6-fold (0.98 log units) below, and the stated range ends below it.
By their numbers in this assay, from the lowest: compound 2; then compounds 3 and 1 (each within the scatter of the next).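

In this assay, 1H-benzimidazol-2-yl on the aromatic nitrogen, in place of pyridin-4-yl, brings a 7.0-fold higher number from compound 2 to compound 3 (0.85 log units; beyond the scatter) and so weaker inhibition. The same group lowered the number when it replaced cyano on an aromatic carbon, so in these compounds its effect depends on where it sits. Nothing available explains this difference between the two places.

Going by these compounds alone, only two groups on this nitrogen can be compared here. As far as these compounds go, how a small methyl group or a saturated piperidine ring would behave at this position remains open.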